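A few compounds are considered here, and "the series" means these few. Any claim that something is new, unique, unknown or untested is made for them only; others in the source may bear on it.

Compound 3 `CCCS(=O)(=O)Nc1ccc(F)c(C(=O)c2n[nH]c3ncc(-c4ccc(C(F)(F)F)cc4)cc23)c1F` stands at the top of the three numbers in an assay for binding affinity to dual specificity mitogen-activated protein kinase kinase 4 (Homo sapiens), read by KINOMEscan, tested at 100 nM; on this read-out higher numbers stand for a weaker effect at the one concentration tested and lower numbers for a stronger effect: compound 3 gives 29%. Compound 1 `CCCS(=O)(=O)Nc1ccc(F)c(C(=O)c2n[nH]c3ncc(-c4ccc(F)cc4)cc23)c1F` gives 2.1% in this assay, and compound 2 `CCCS(=O)(=O)Nc1ccc(F)c(C(=O)c2n[nH]c3ncc(-c4ccc(Cl)c(C(F)(F)F)c4)cc23)c1F` gives 15%. The steps that connect them all point the same way, away from the 4-fluorophenyl of compound 1: a number 12.9 percentage points higher from compound 1 to compound 2 (beyond the scatter), a number 26.9 percentage points higher from compound 1 to compound 3 (beyond the scatter) and a number 14 percentage points higher from compound 2 to compound 3 (beyond the scatter). Compound 3 is thus the weakest of the three in this assay.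

Compound 4 `CCCS(=O)(=O)Nc1ccc(F)c(C(=O)c2n[nH]c3ncc(-c4ccc(S(N)(=O)=O)cc4Cl)cc23)c1F` differs from compound 3 at the same aryl ring: 2-chloro-4-sulfamoylphenyl in place of 4-(trifluoromethyl)phenyl on an aromatic carbon. Among the measured compounds shown here, none of the measured steps brings in a sulfamoyl group or a 2-chloro substituent, so no step speaks directly to this change. What the measured steps do show is that exchanges on this ring have moved the read-out by modest amounts, and that every departure from 4-fluorophenyl has raised the number. Since compound 3 already holds the highest value and the new group bears no trifluoromethyl, a modest fall is expected, about a number 14 percentage points lower from compound 3 to compound 4 (beyond the scatter), though the direction remains uncertain. Compound 4 is estimated at 15%, with a range from 2% to 50%.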

Compound 4, a percentage reported as activity, at one concentration (the size of the read-out at that concentration, not a potency): 3.4%
Compound 4: the middle estimate sits 11.6 percentage points above what was measured; the measured number falls inside the stated range.
By their numbers in this assay, from the lowest: compounds 1 and 4 (each within the scatter of the next); then compound 2; then compound 3.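

In this assay, among the compounds shown here, the 2-chloro-4-sulfamoylphenyl group is the first departure from the 4-fluorophenyl of compound 1 that does not raise the number: the step is a number 1.3 percentage points higher from compound 1 to compound 4 (within the scatter) and so gives no separation, whereas the two earlier departures both gave higher numbers. The same group also gives lower numbers than both trifluoromethyl-bearing aryl groups, with a number 25.6 percentage points lower from compound 3 to compound 4 (beyond the scatter) and a number 11.6 percentage points lower from compound 2 to compound 4 (beyond the scatter) as the two steps. At this position, then, a higher number does not follow from every change away from 4-fluorophenyl, and among the four compounds shown the two with a trifluoromethyl group on this ring, compound 2 and compound 3, have the highest numbers, with no compound going against this.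

The compounds shown do not separate the sulfamoyl group from the 2-chloro substituent, so a plain 4-sulfamoylphenyl or 2-chlorophenyl, or a 4-aminophenyl or 4-carboxyphenyl, could show which part matters. No measurement given here accounts for these differences.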